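The source may report more compounds than this note shows. Statements on the series, on what has been measured and on what is new or still open speak of the compounds shown alone.

Compound 3 `Cc1c(C(=O)NCCCN2CCN(C)CC2)c(-c2cccc(N3CCN(c4ccc(NS(=O)(=O)c5cccc(OC(F)(F)F)c5)cc4)CC3)c2)c(-c2ccc(Cl)cc2)n1C` gives 763 nM in an assay for inhibition of Apoptosis regulator Bcl-2 (Homo sapiens), read by fluorescence polarization, with a stated time of 2 h (on this read-out lower numbers stand for stronger inhibition and higher numbers for weaker inhibition), the lowest of the three numbers. Compound 1 `Cc1c(C(=O)NCCCN2CCN(C)CC2)c(-c2cccc(N3CCN(c4ccc(NS(=O)(=O)c5cccc(S(=O)(=O)C6CC6)c5)cc4)CC3)c2)c(-c2ccc(Cl)cc2)n1C` gives 844 nM, and a 1.1-fold lower number from compound 1 to compound 3 (0.04 log units; within the scatter), so no order between the two is claimed. Compound 2 `Cc1c(C(=O)NCCCN2CCN(C)CC2)c(-c2cccc(N3CCN(c4ccc(NS(=O)(=O)c5cccc(OC(C)C)c5)cc4)CC3)c2)c(-c2ccc(Cl)cc2)n1C` gives 2020 nM, with a 2.6-fold lower number from compound 2 to compound 3 (0.42 log units; beyond the scatter) and a 2.4-fold higher number from compound 1 to compound 2 (0.38 log units; beyond the scatter) both modest. Compound 4 `CCOc1cccc(S(=O)(=O)Nc2ccc(N3CCN(c4cccc(-c5c(C(=O)NCCCN6CCN(C)CC6)c(C)n(C)c5-c5ccc(Cl)cc5)c4)CC3)cc2)c1` carries ethyl in place of trifluoromethyl on an oxygen on an aromatic ring. The step that bears on this is the exchange on the same oxygen, a 2.6-fold lower number from compound 2 to compound 3 (0.42 log units; beyond the scatter); read the other way, an alkyl on that oxygen gave the higher number, and ethyl, like isopropyl, is an alkyl group, so an upward step of similar or somewhat smaller size is expected. For compound 4 the expected result is 1500 nM, within 700 nM to 3200 nM, corresponding to a 2.0-fold higher number from compound 3 to compound 4 (0.29 log units; within the scatter).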

Compound 4, half-maximal inhibitory concentration: 1620 nM
Estimate against measurement, compound 4: 1.1-fold (0.03 log units) below, within the range that was stated.
By their numbers in this assay, from the lowest: compounds 3, 1, 4 and 2 (each within the scatter of the next, the first and the last beyond it).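

In this assay, ethyl on this oxygen moves the number the same way as isopropyl did relative to trifluoromethyl (a 2.1-fold higher number from compound 3 to compound 4 (0.33 log units; beyond the scatter)). Shortening isopropyl to ethyl does not separate the two alkoxy groups (a 1.2-fold lower number from compound 2 to compound 4 (0.10 log units; within the scatter)). Ethoxy and cyclopropylsulfonyl are not separated either (a 1.9-fold higher number from compound 1 to compound 4 (0.28 log units; within the scatter)), and no supporting data account for these steps.

Open, going by these compounds, is whether the trend holds beyond ethyl and isopropyl, for example with methoxy or difluoromethoxy on this aromatic carbon. Also open, on these data alone, is how a hydroxyl, an amine or a carboxylic acid would read there.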